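This account rests on a few compounds, and the source may have more. Where it says the series, first, only, none or still open, it means among the compounds named here.

Of the compounds shown here, two have so far been measured in a functional assay on A-375 cells (Homo sapiens) for cytotoxicity, read by MTT assay, with a stated time of 48 h; on this read-out higher numbers stand for weaker inhibition and lower numbers for stronger inhibition. Compound 1, `CC1(C)[C@H](C(=O)OC(c2ccccc2)c2ccccc2)N2C(=O)/C(=C/C(=O)c3ccccc3)[C@H]2S1(=O)=O`, gives 17500 nM in this assay. Compound 2, `CC1(C)S[C@@H]2/C(=C\C(=O)c3ccc([N+](=O)[O-])cc3)C(=O)N2[C@H]1C(=O)OC(c1ccccc1)c1ccccc1`, gives 50300 nM in this assay. Of these two numbers, compound 2 holds the higher one, which on this read-out means the weaker inhibition, and its gap to compound 1 lies beyond the usual scatter of repeated measurements.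

Compound 3, `CC1(C)S[C@@H]2/C(=C\C(=O)c3ccc(F)cc3)C(=O)N2[C@H]1C(=O)OC(c1ccccc1)c1ccccc1`, has not yet been measured. It differs from compound 2 in a single place: fluoro in place of nitro on an aromatic carbon. Within the data shown here, no measured pair in this set shows the same exchange, so its effect here is unknown. Starting from the value of compound 2, 50300 nM in this assay, compound 3 is expected to land near 28000 nM, with a range from 9000 nM to 90000 nM. That expectation corresponds to a step of a 1.8-fold lower number from compound 2 to compound 3 (0.25 log units; within the scatter), a small move toward stronger inhibition that may well stay within the scatter.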

Compound 3, half-maximal inhibitory concentration: 17800 nM
Compound 3: the middle estimate sits 1.6-fold (0.20 log units) above what was measured, and the stated range covers the measured number.
By their numbers in this assay, from the lowest: compounds 1 and 3 (each within the scatter of the next); then compound 2.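

Exchanging nitro for fluoro on the aromatic carbon gives a 2.8-fold lower number from compound 2 to compound 3 (0.45 log units; beyond the scatter) in this assay, a modest move toward stronger inhibition. Among these compounds, compound 2 and compound 3 form the first pair here that differs in one place only, so this result shows that the group on this six-membered aromatic ring of carbon only, para to a large group, can shift the read-out beyond the scatter while the rest of the molecule stays the same. Nothing measured on these two groups explains the step.

A single exchange cannot tell whether the gain comes from losing nitro or from gaining fluoro, and a plain hydrogen at this position on the core of compound 2 would help separate the two. Also open, going by these compounds, is how other groups would behave at this position, such as chloro, methoxy, an amine or a carboxylic acid, and whether fluoro would give a similar step on the core of compound 1.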